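Adding trifluoromethoxy to a hydroxy-bearing growth inhibitor

The compounds below may be only part of what the source reports. "The series", "measured", "known", "first", "only" and "open" are said of these compounds alone.

Measured in a functional assay on ZR-75-1 cells (Homo sapiens) for inhibition, read by sulforhodamine B assay; a lower number here means a stronger inhibitor of growth, a higher number a weaker inhibitor of growth:
- compound 1 `c1ccc(-c2ccc(-c3ccc(-c4nc5ccccc5[nH]4)cc3)cc2)cc1`: 100000 nM
- compound 2 `COc1ccc(-c2ccc(-c3ccc(-c4nc5ccccc5[nH]4)cc3)cc2)cc1`: 35100 nM
- compound 3 `Oc1cccc2[nH]c(-c3ccc(-c4ccc(-c5ccccc5)cc4)cc3)nc12`: 35600 nM

The values of compound 2 and compound 3 lie within the scatter of each other, so these two cannot be told apart. The hydroxy group separates compound 3 from the unsubstituted parent, and that measured change is a 2.8-fold lower number from compound 1 to compound 3 (0.45 log units; beyond the scatter).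

Compound 4 `Oc1cccc2[nH]c(-c3ccc(-c4ccc(-c5ccc(OC(F)(F)F)cc5)cc4)cc3)nc12` differs from compound 3 in one place: trifluoromethoxy in place of hydrogen on an aromatic carbon. This puts trifluoromethoxy in place of hydrogen on an aromatic carbon, para to a large group.

Going by the values given here, the closest precedent is the swap of hydrogen for methoxy, a 2.8-fold lower number from compound 1 to compound 2 (0.45 log units; beyond the scatter), a modest step. Among the compounds with values here, no measured compound carries a fluorinated group, and none carries two added groups, so this precedent is only a loose guide. In this assay, a similarly modest move toward a lower number is therefore expected, and the estimated step is a 2.4-fold lower number from compound 3 to compound 4 (0.38 log units; beyond the scatter). For compound 4 the estimated value is 15000 nM, with an expected range from 4000 nM to 60000 nM.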

Compound 4, concentration for 50% growth inhibition: 3800 nM
For compound 4 the middle estimate is 3.9-fold (0.60 log units) above the measured one, outside the stated range (below it).
By their numbers in this assay, from the lowest: compound 4; then compounds 2 and 3 (each within the scatter of the next); then compound 1.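

In this assay, putting trifluoromethoxy on an aromatic carbon, para to a large group, gives a 9.4-fold lower number from compound 3 to compound 4 (0.97 log units; beyond the scatter). This shows that the number can still fall when a second added group joins the hydroxy group on one molecule, something compound 1, compound 2 and compound 3, each with at most one added group, could not show. Nothing measured here explains why the step has this size.

Still open, from the compounds shown here alone, is whether trifluoromethoxy would give a similar step on compound 1, which lacks the hydroxy group, and so whether the two groups act independently. Also open, going by these compounds, is how an amine, a carboxylic acid or a longer alkyl chain at the same place would compare with trifluoromethoxy.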